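Proline-amide series: cyclopropane-fused core with methoxy-dimethyl carbinol

The source may hold more compounds than are shown below. What is called first, only, known or untested is meant among the compounds shown, and "the series" means these compounds.

Three compounds of the series have been run in a functional assay on a cell-free system (plasma, Homo sapiens), with a stated time of 3 min (on this read-out higher numbers stand for weaker inhibition and lower numbers for stronger inhibition), so far. Compound 1 `CC(C)(C)[C@@H](O)C(=O)N1CSC[C@H]1C(=O)NCc1cc(Cl)ccc1-n1cnnn1` gives 1200 nM in this assay, and compound 2 `CC(C)(C)C[C@@H](O)C(=O)N1OCC[C@H]1C(=O)NCc1cc(Cl)ccc1-n1cnnn1` gives 1100 nM. Compound 3 `O=C(NCc1cc(Cl)ccc1-n1cnnn1)[C@@H]1[C@@H]2C[C@@H]2CN1C(=O)[C@H](O)Cc1ccccn1` gives 1700 nM; its number sits alongside those of compound 1 and compound 2, with no gap to either that reaches beyond the usual scatter, so the three cannot be told apart on these data.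

Compound 4 `COC(C)(C)[C@@H](O)C(=O)N1C[C@H]2C[C@H]2[C@H]1C(=O)NCc1cc(Cl)ccc1-n1cnnn1` keeps the core of compound 3 and changes the side chain on the hydroxy acid part: 1-methoxy-1-methylethyl in place of (pyridin-2-yl)methyl on a saturated chain carbon bound to a carbonyl carbon and an oxygen on a saturated carbon. The group entering resembles the saturated branched groups carried by compound 1 and compound 2 more than the aromatic group carried by compound 3, and all three of those compounds fall within scatter of one another in this assay. Among the measured compounds shown here, there is no measured pair that isolates this kind of exchange, so nothing supports a step beyond the scatter in either direction.

Compound 4 is therefore expected to land close to compound 3, with a step of a 1.3-fold lower number from compound 3 to compound 4 (0.12 log units; within the scatter) that is estimated to stay within the scatter. The estimate for compound 4 in this assay is 1300 nM, with a range from 600 nM to 3000 nM.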

Compound 4, half-maximal inhibitory concentration: 1000 nM
The estimate for compound 4 lay 1.3-fold (0.11 log units) above the measured number; low and high end bracket the measured number.
By their numbers in this assay, from the lowest: compounds 4, 2, 1 and 3 (each within the scatter of the next).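

In this assay, the exchange on a saturated chain carbon bound to a carbonyl carbon and an oxygen on a saturated carbon gives a 1.7-fold lower number from compound 3 to compound 4 (0.23 log units; within the scatter) on the shared core. Among the compounds shown here, this is the first comparison at this position in which only one place differs, and it does not separate 1-methoxy-1-methylethyl from (pyridin-2-yl)methyl. A number in this range therefore does not depend on the six-membered aromatic ring at this position, even with the group going from 7 heavy atoms to 5. No measurement at hand accounts for the two groups reading alike.

Still open, as far as these compounds go, is whether any group at this position can move the number beyond the scatter on this core; a carboxylic acid, a primary amine or a longer alkyl chain in place of 1-methoxy-1-methylethyl would test that. Also open, from the compounds shown here alone, is whether the oxygen of the 1-methoxy-1-methylethyl group contributes at all, a question that an isopropyl group in its place on the shared core would address directly.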